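Fluorophenyl to methoxyphenyl on the amide-linked benzyl group

The source may hold more compounds than are shown below. What is called first, only, known or untested is meant among the compounds shown, and "the series" means these compounds.

Measured compounds:
compound 1 `COc1ccc(CNC(=O)/C=C/c2coc3cc(O)ccc3c2=O)cc1`: 8430 nM
compound 2 `COc1ccc2c(=O)c(/C=C/C(=O)NCc3ccccc3)coc2c1`: 13600 nM
compound 3 `COc1ccc2c(=O)c(/C=C/C(=O)NCc3cccc(F)c3)coc2c1`: 10100 nM

In a functional assay on Huh-7 cells (Homo sapiens) for inhibition, read by MTT assay, with a stated time of 48 h (on this read-out higher numbers stand for weaker inhibition and lower numbers for stronger inhibition), compound 3 stands second highest of the three numbers, with compound 1 nearest and compound 2 furthest, both within the scatter. Compound 4 `COc1ccc(CNC(=O)/C=C/c2coc3cc(OC)ccc3c2=O)cc1` is not yet measured; it differs from compound 3 by 4-methoxyphenyl in place of 3-fluorophenyl on a saturated chain carbon bound to an amide-type nitrogen. For the measured compounds named here, the only measured step on this side of the molecule, a 1.3-fold lower number from compound 2 to compound 3 (0.13 log units; within the scatter), shows that a change on this ring left this assay essentially unmoved. Compound 1, which also carries the 4-methoxyphenyl group, gives 8430 nM. On this basis, compound 4 is expected to show no step beyond the scatter, a 1.1-fold lower number from compound 3 to compound 4 (0.03 log units; within the scatter), with an estimated value of 9500 nM (range 4500 nM to 20000 nM).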

Compound 4, half-maximal inhibitory concentration: 7570 nM
Compound 4: the middle estimate sits 1.3-fold (0.10 log units) above what was measured; measured number inside the range.
By their numbers in this assay, from the lowest: compounds 4, 1, 3 and 2 (each within the scatter of the next).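

In this assay, the change from 3-fluorobenzyl to 4-methoxybenzyl gives a 1.3-fold lower number from compound 3 to compound 4 (0.13 log units; within the scatter) and methoxy in place of hydrogen on the benzyl ring gives a 1.8-fold lower number from compound 2 to compound 4 (0.25 log units; within the scatter) so this position has now carried three different rings without a step beyond the scatter. The second site changes little as well: methyl in place of hydrogen on an oxygen on an aromatic ring gives a 1.1-fold lower number from compound 1 to compound 4 (0.05 log units; within the scatter) and this too stays within the scatter.

From the compounds shown here alone, whether an amine or a carboxylic acid on the benzyl ring, or a longer chain in place of the benzyl carbon, would move the number beyond the scatter remains open. No evidence is available to explain why these numbers stay so close.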